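Series notes: amide variation on the chlorinated lactam core

The compounds below may be only part of what the source reports. "The series", "measured", "known", "first", "only" and "open" are said of these compounds alone.

Measured so far:
Compound 1 `N[C@@H](C(=O)Nc1cc2cc[nH]c(=O)c2cc1Cl)C1CCCCC1`: 400 nM
Compound 2 `CN(C)[C@H]1CC[C@@H](C(=O)Nc2cc3cc[nH]c(=O)c3cc2Cl)CC1`: 1000 nM
Compound 3 `CC(C)[C@@H](N)C(=O)Nc1cc2cc[nH]c(=O)c2cc1Cl`: 240 nM

All three numbers come from an assay on isolated protein for inhibition of Rho-associated protein kinase 2 (Homo sapiens); a higher number here means a weaker inhibitor, a lower number a stronger inhibitor. Compound 3 has the lowest of the three, but its nearest neighbour is compound 1, and the step of a 1.7-fold lower number from compound 1 to compound 3 (0.22 log units; within the scatter) sits within the scatter, so the two cannot be ranked. Compound 2 lies beyond the scatter above compound 3; it differs from compound 3 in more than one place, so only the two values themselves can be compared.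

Compound 4 `O=C(Nc1cc2cc[nH]c(=O)c2cc1Cl)[C@@H]1CCCN1` is not yet measured. It differs from compound 3 by pyrrolidin-2-yl in place of 1-amino-2-methylpropyl on a carbonyl carbon. Within the data shown here, the only measured step that touches this region, the isopropyl for cyclohexyl exchange a 1.7-fold lower number from compound 1 to compound 3 (0.22 log units; within the scatter), was within the scatter, which suggests that variation on the carbon bearing the amine is tolerated. Among the measured compounds shown here, no measured pair ties the amine nitrogen into a ring with that carbon, so the effect of closing the five-membered ring is not covered by the data.

The expected step is a 1.3-fold higher number from compound 3 to compound 4 (0.10 log units; within the scatter), estimated as no change beyond the scatter. The estimate for compound 4 in this assay is 300 nM, with a range from 120 nM to 800 nM.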

Compound 4, half-maximal inhibitory concentration: 35 nM
For compound 4 the middle estimate is 8.6-fold (0.93 log units) above the measured one; the whole stated range lies above it.
By their numbers in this assay, from the lowest: compound 4; then compounds 3 and 1 (each within the scatter of the next); then compound 2.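

In this assay, among these compounds, pyrrolidin-2-yl in place of 1-amino-2-methylpropyl on a carbonyl carbon gives a 6.9-fold lower number from compound 3 to compound 4 (0.84 log units; beyond the scatter), the first step at this position to lie beyond the scatter. The earlier exchange at the chain carbon, isopropyl in place of cyclohexyl, gave a 1.7-fold lower number from compound 1 to compound 3 (0.22 log units; within the scatter), so that step alone did not show that the series responds to changes in this substituent. The leaving and entering groups match in heavy atoms, hydrogen-bond donors, hydrogen-bond acceptors and defined stereocentres, and the one counted difference is the five-membered non-aromatic ring, although no information is available to explain the size of the step.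

The compounds shown do not tell whether the gain depends on ring size, which azetidin-2-yl or piperidin-2-yl would address, or whether it survives a methyl group on the ring nitrogen. Going by these compounds, the opposite configuration at the defined stereocentre of pyrrolidin-2-yl also remains open, as does any gain from a hydroxyl or fluoro substituent on that ring.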